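The source may report more compounds than this note shows. Statements on the series, on what has been measured and on what is new or still open speak of the compounds shown alone.

In an ADME assay on Vero 76 cells (Chlorocebus sabaeus) for cytotoxicity, read by MTT assay, with a stated time of 96 h (on this read-out lower numbers stand for higher toxicity in this test and higher numbers for lower toxicity in this test), compound 1 (`FC(F)(F)c1ccc(NCc2cn(-c3ccccc3)nc2-c2ccc(C(F)(F)F)cc2)cc1`) gives 26000 nM and compound 2 (`Cc1ccc(-c2nn(-c3ccccc3)cc2CNc2ccc(Br)cc2)cc1`) gives 92000 nM as the higher of the two numbers, with the gap beyond the scatter. Compound 3 (`FC(F)(F)c1ccc(-c2nn(-c3ccccc3)cc2CNc2ccc(Br)cc2)cc1`) differs from compound 2 by trifluoromethyl in place of methyl on an aromatic carbon. Within the data shown here, no measured pair isolates this change. Compound 1 also carries 4-(trifluoromethyl)phenyl and stands at 26000 nM but differs elsewhere too, so it is only a weak pointer towards a lower number. In this assay the expected step is a 1.8-fold lower number from compound 2 to compound 3 (0.26 log units; within the scatter) as a modest drop near the edge of the scatter. Compound 3 is expected at 50000 nM (20000 nM to 100000 nM).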

Compound 3, half-maximal cytotoxic concentration: 17000 nM
Beside the measured number, compound 3's estimate is 2.9-fold (0.47 log units) above it, and the stated range ends above it.
By their numbers in this assay, from the lowest: compounds 3 and 1 (each within the scatter of the next); then compound 2.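

In this assay, a matched pair now isolates 4-methylphenyl to 4-(trifluoromethyl)phenyl para to a large group, and it gives a change beyond the scatter (a 5.4-fold lower number from compound 2 to compound 3 (0.73 log units; beyond the scatter)). With 4-(trifluoromethyl)phenyl held constant, bromo in place of trifluoromethyl on an aromatic carbon stays within the scatter (a 1.5-fold lower number from compound 1 to compound 3 (0.18 log units; within the scatter)). Nothing available explains either result.

Still open, from the compounds shown here alone, is how an amine or a carboxylic acid in place of trifluoromethyl at this position would read. Also open, going by these compounds, is whether the step from methyl to trifluoromethyl holds without bromo elsewhere in the compound.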